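An Amino Group Added to the Core of Compound 1

The source may hold more compounds than are shown below. What is called first, only, known or untested is meant among the compounds shown, and "the series" means these compounds.

Compound 1, `O=C(COc1cccc2ccccc12)N1CCCC1`, gives 51.6% in a functional assay on the whole organism with Mus musculus as the target, in the elevated plus maze, with a stated time of 24 h, at a dose of 1 mg/kg by the intraperitoneal route; a higher number here means a stronger effect of the compound at the dose given, a lower number a weaker effect.
Compound 2, `O=C(COc1cccc2ccccc12)N1CCOCC1`, gives 62.7% in this assay.

Of the two numbers, compound 1 stands lowest; compound 2 sits above it by a number 11.1 percentage points higher from compound 1 to compound 2 (beyond the scatter), a step that swaps one ring for another on the carbonyl carbon and leaves the rest of the molecule untouched.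

Compound 3, `Nc1cccc2c(OCC(=O)N3CCCC3)cccc12`, differs from compound 1 in a different place: amino in place of hydrogen on an aromatic carbon. Going by the values given here, the only measured step, from compound 1 to compound 2, concerns the ring on the carbonyl carbon, not the aromatic ring, so it gives no guidance on what an amino group there will do. Among the compounds with values here, no compound with any change on the aromatic ring has been measured, so there is nothing to point the new step up or down.

Within the data shown here, with no step bearing on it, compound 3 is expected to show about a number 0.4 percentage points higher from compound 1 to compound 3 (within the scatter) in this assay, that is, no change beyond the scatter. The estimate for compound 3 is 52%, within a wide range from 30% to 75%, reflecting the lack of any measured change at that place.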

Compound 3, a percentage reported as activity, at one dose (the size of the read-out at that dose, not a potency): 69.1%
For compound 3 the middle estimate is 17.1 percentage points below the measured one; the range from low to high includes it.
By their numbers in this assay, from the lowest: compound 1; then compounds 2 and 3 (each within the scatter of the next).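

The aromatic ring of the core of compound 1 proves to be a place where a change shows up in this assay: amino in place of hydrogen on an aromatic carbon gives a number 17.5 percentage points higher from compound 1 to compound 3 (beyond the scatter) and lies beyond the usual scatter. Going by these compounds alone, until this result, the only step that could be read concerned the ring on the carbonyl carbon, so this is the first sign that the aromatic ring also matters, with the pyrrolidin-1-yl ring left as it was. The step describes the size of the read-out at a single dose, not a potency, and no measurement on these compounds explains how the amino group produces it.

The compounds shown leave open whether the rise belongs to amino itself or would also follow from another group at this place, such as a hydroxyl, a methoxy or an acetamide, and whether other carbons of the aromatic ring respond in the same way. They also leave open what amino would do on the core of compound 2, where morpholin-4-yl stands in place of pyrrolidin-1-yl.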